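Shortening a Pentyl Chain to Propyl on a Triazole

A few compounds are considered here, and "the series" means these few. Any claim that something is new, unique, unknown or untested is made for them only; others in the source may bear on it.

Of the compounds shown here, three sharing one core have been measured in an ADME assay on HeLa cells (Homo sapiens) for cytotoxicity, read by sulforhodamine B assay, with a stated time of 48 h, tested at 10 uM; on this read-out lower numbers stand for less inhibition and higher numbers for more inhibition at the one concentration tested (going by the name of the read-out). Compound 1 `COc1nc2ccc(Br)cc2cc1C(c1ccccc1)n1cc(-c2ccc(Br)cc2)nn1` gives 6.92%, compound 2 `COc1nc2ccc(Br)cc2cc1C(c1ccccc1)n1cc(CCO)nn1` gives 0.85%, and compound 3 `CCCCCc1cn(C(c2ccccc2)c2cc3cc(Br)ccc3nc2OC)nn1` gives -9.81%. On these numbers compound 3 stands lowest: the move from compound 1 to compound 3 was a number 16.7 percentage points lower from compound 1 to compound 3 (beyond the scatter), and from compound 2 to compound 3 it was a number 10.7 percentage points lower from compound 2 to compound 3 (beyond the scatter), both reaching beyond the scatter of the method, while a number 6.1 percentage points lower from compound 1 to compound 2 (within the scatter) stayed within it.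

Compound 4 `CCCc1cn(C(c2ccccc2)c2cc3cc(Br)ccc3nc2OC)nn1` differs from compound 3 in one place: hydrogen in place of ethyl on a saturated chain carbon, three bonds along the chain from an aromatic carbon. Within the data shown here, no measured step trims the end of a saturated chain in this way. The nearest comparison is the step from compound 2 to compound 3, which exchanged hydroxy for propyl on the chain, and it stayed modest. A change smaller than that, removing only two carbons at the far end of the chain, is expected to give a step of a number 4.8 percentage points higher from compound 3 to compound 4 (within the scatter) in this assay, that is, nothing beyond the scatter. Compound 4 is therefore estimated at -5%, with a likely range from -20% to 8%.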

Compound 4, a percentage reported as inhibition, at one concentration (the size of the read-out at that concentration, not a potency): -2.25%
Estimate against measurement, compound 4: 2.8 percentage points below, and the stated range covers the measured number.
By their numbers in this assay, from the lowest: compounds 3, 4, 2 and 1 (each within the scatter of the next, the first and the last beyond it).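

This is the only step shown that changes the length of the chain and nothing else, and trimming pentyl to propyl gives a number 7.6 percentage points higher from compound 3 to compound 4 (within the scatter) in this assay. With propyl at this position, the separation seen for the pentyl chain disappears: there is a number 3.1 percentage points lower from compound 2 to compound 4 (within the scatter) and a number 9.2 percentage points lower from compound 1 to compound 4 (within the scatter), so the propyl chain cannot be told apart from either the 2-hydroxyethyl or the 4-bromophenyl group on these numbers. No measurement here offers an explanation for these differences.

The compounds shown leave open whether a chain ending in an amine or a carboxylic acid would give a number beyond the scatter of compound 4. They also leave open what a methyl group, or a chain longer than pentyl, would give at this position.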